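Swapping a chloro for a benzyloxy group on compound 1

The compounds below may be only part of what the source reports. "The series", "measured", "known", "first", "only" and "open" are said of these compounds alone.

Of the compounds shown here, two have been tested in a functional assay on HepG2 cells (Homo sapiens) for antiproliferative activity, read by MTT assay, with a stated time of 48 h; on this read-out higher numbers stand for weaker inhibition and lower numbers for stronger inhibition. Among the compounds with values here, compound 1 `O=C(CN1CCCC1)Nc1ccc2ncnc(Nc3ccc(Cl)cc3)c2c1` gives 18000 nM in this assay, the only plain number recorded so far. Compound 2 `CN1CCN(CC(=O)Nc2ccc3ncnc(Nc4ccc(Cl)cc4)c3c2)CC1`, which carries 4-methylpiperazin-1-yl in place of pyrrolidin-1-yl on a saturated chain carbon bound to a carbonyl carbon, reaches only a limit of the assay: compound 2 gives > 100000 nM in this assay. That change gives an at least 5.5-fold higher number from compound 1 to compound 2 (0.74 log units; beyond the scatter), with the result sitting at the limit of > 100000 nM in this assay, at which 1 of the 2 values shown sits.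

The unmeasured compound 3 `O=C(CN1CCCC1)Nc1ccc2ncnc(Nc3ccc(OCc4cccc(F)c4)cc3)c2c1` keeps the pyrrolidin-1-yl side of compound 1 and alters the other end: (3-fluorobenzyl)oxy in place of chloro on an aromatic carbon. Within the data shown here, no measured step touches this position, since the step from compound 1 to compound 2 changes only the saturated amine, so the recorded data give no direct guide to its size or direction. On that basis compound 3 is expected to give 10000 nM in this assay, between 2000 nM and 50000 nM. The change from compound 1 to compound 3 is therefore expected to be a 1.8-fold lower number from compound 1 to compound 3 (0.26 log units; within the scatter), kept wide for want of a comparable measured step.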

Compound 3, half-maximal inhibitory concentration: 25100 nM
Estimate against measurement, compound 3: 2.5-fold (0.40 log units) below; measured number inside the range.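

In this assay, (3-fluorobenzyl)oxy in place of chloro on this aromatic carbon gives a 1.4-fold higher number from compound 1 to compound 3 (0.14 log units; within the scatter). Within the data shown here, this is the first information about this end of the molecule, and it shows that a group of 9 heavy atoms, bringing a six-membered aromatic ring of its own, can replace a single chlorine atom without a difference that stands out from the usual scatter of repeated measurements, whereas the earlier step at the saturated amine did lie beyond the scatter. Nothing recorded here offers a reason for this outcome.

A single pair cannot show whether the fluorine matters, so plain benzyloxy would be informative, as would smaller groups at the same place, such as methoxy or an amine. Going by these compounds, it also remains open whether (3-fluorobenzyl)oxy would behave in the same way with 4-methylpiperazin-1-yl at the other end of the molecule, or whether a different saturated amine, such as morpholine, could give stronger inhibition in this assay.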